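One amide-nitrogen swap and an expected read-out

The source may report more compounds than this note shows. Statements on the series, on what has been measured and on what is new or still open speak of the compounds shown alone.

Compound 1 `CC(=O)Oc1ccc(-c2ccc(F)cc2F)cc1C(=O)Nc1ccccc1` gives 8.9% in a functional assay on the whole organism (strain Kunming) for inhibition, with Mus musculus as the target, in the writhing test, at a dose of 40 mg/kg by the oral route; on this read-out lower numbers stand for less inhibition and higher numbers for more inhibition at the one dose given (going by the name of the read-out). Compound 2 `CC(=O)Oc1ccc(-c2ccc(F)cc2F)cc1C(=O)Nc1cc(C)ccc1C` gives 13.2%.

Compound 2 sits alongside compound 1, the two numbers lying within the usual scatter of each other, so neither can be set apart. Compound 3 `CC(=O)Oc1ccc(-c2ccc(F)cc2F)cc1C(=O)NN1CCOCC1` differs from compound 2 by morpholin-4-yl in place of 2,5-dimethylphenyl on an amide-type nitrogen. Going by the values given here, the only measured step that also alters the group on the amide-type nitrogen is a number 4.3 percentage points higher from compound 1 to compound 2 (within the scatter), which stayed within the scatter. Among the compounds with values here, no measured step replaces an aromatic ring with a non-aromatic one, so this change is untested. The expected step is a number 1.2 percentage points lower from compound 2 to compound 3 (within the scatter), small in either direction. Compound 3 is estimated at 12% in this assay, between 0% and 30%.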

Compound 3, a percentage reported as inhibition, in the whole organism at one dose (the size of the read-out at that dose, not a potency): 28.5%
Compound 3: the middle estimate sits 16.5 percentage points below what was measured; the measured number falls inside the stated range.
By their numbers in this assay, from the lowest: compounds 1 and 2 (each within the scatter of the next); then compound 3.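

In this assay the group on the amide-type nitrogen now shows a clear effect: morpholin-4-yl in place of 2,5-dimethylphenyl gives a number 15.3 percentage points higher from compound 2 to compound 3 (beyond the scatter) and morpholin-4-yl in place of phenyl gives a number 19.6 percentage points higher from compound 1 to compound 3 (beyond the scatter) on the same core. This position therefore responds to a change from an aromatic carbon ring to a non-aromatic ring with hetero atoms. Nothing at hand explains why the number rises with this change.

The compounds shown leave open whether the ring oxygen or the ring nitrogen of morpholin-4-yl matters for this rise. A piperidin-1-yl group or an open-chain dimethylamino group at the same place would help to separate these possibilities.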